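Pyridine for fluorophenyl on a chalcone: an expected step

The compounds below may be only part of what the source reports. "The series", "measured", "known", "first", "only" and "open" are said of these compounds alone.

Measured compounds:
compound 1, `COc1cc(C(=O)/C=C/c2ccccc2-c2ccc(F)cc2)ccc1O`, 4600 nM
compound 2, `COc1cc(C(=O)/C=C/c2ccccc2-c2ccc(F)nc2)ccc1O`, 13000 nM
compound 3, `COc1ccc(C(=O)/C=C/c2ccccc2-c2ccc(F)cc2)cc1O`, 940 nM

Of the compounds shown here, three have been measured in a functional assay on A549 cells (Homo sapiens) for antiproliferative activity, read by sulforhodamine B assay, with a stated time of 48 h; on this read-out lower numbers stand for stronger inhibition and higher numbers for weaker inhibition. Compound 1 has the structure `COc1cc(C(=O)/C=C/c2ccccc2-c2ccc(F)cc2)ccc1O` and gives 4600 nM. Compound 2, with the structure `COc1cc(C(=O)/C=C/c2ccccc2-c2ccc(F)nc2)ccc1O`, gives 13000 nM. The change between them is 6-fluoropyridin-3-yl in place of 4-fluorophenyl on an aromatic carbon and it produced a 2.8-fold higher number from compound 1 to compound 2 (0.45 log units; beyond the scatter).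

Compound 3, `COc1ccc(C(=O)/C=C/c2ccccc2-c2ccc(F)cc2)cc1O`, has the same atoms as compound 1 joined differently; the difference between the two cores is not broken down here. In this assay compound 3 gives 940 nM, the lowest of the three numbers.

Compound 4, `COc1ccc(C(=O)/C=C/c2ccccc2-c2ccc(F)nc2)cc1O`, has not yet been measured. It stands to compound 3 as compound 2 stands to compound 1: the change is 6-fluoropyridin-3-yl in place of 4-fluorophenyl on an aromatic carbon, the same kind of change at the same kind of place, and it is seen only once among the measured pairs. The expectation for compound 4 therefore rests on a single precedent, the step of a 2.8-fold higher number from compound 1 to compound 2 (0.45 log units; beyond the scatter), read onto the core of compound 3.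

On that basis compound 4 is expected to show a step of about a 2.8-fold higher number from compound 3 to compound 4 (0.44 log units; beyond the scatter) in this assay. For the measured compounds named here, compound 4 is estimated at 2600 nM, with a plausible range from 1200 nM to 6000 nM, the width reflecting that only one example of this change is known.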

Compound 4, half-maximal inhibitory concentration: 3200 nM
For compound 4 the middle estimate is 1.2-fold (0.09 log units) below the measured one; low and high end bracket the measured number.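

In this assay, putting 6-fluoropyridin-3-yl in place of 4-fluorophenyl on the second core gives a 3.4-fold higher number from compound 3 to compound 4 (0.53 log units; beyond the scatter), and this step matches the earlier one on the first core: the same change on two cores in this assay, a 2.8-fold higher number (0.45 log units; beyond the scatter) from compound 1 to compound 2 and a 3.4-fold higher number (0.53 log units; beyond the scatter) from compound 3 to compound 4, 1.2-fold (0.08 log units) apart, within the scatter of two such steps. Within this series, then, the change carried from one core to the other with the same direction and a comparable size, even though the two cores have the same atoms joined differently and start from different values. For the compounds shown here, this rests on only two pairs in a single assay, so it does not show that the step would hold on any further core or in another read-out, and it does not explain why the number rises on either core.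

The compounds shown leave open how other groups would behave at this place on the shared core, such as a pyrimidine ring or a pyridine carrying an amine, a carboxylic acid or a methoxy group where these compounds carry fluorine. They also leave open whether the step would stay the same size with such a group, since only the single pairing of 4-fluorophenyl and 6-fluoropyridin-3-yl has been compared here.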